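The source may hold more compounds than are shown below. What is called first, only, known or untested is meant among the compounds shown, and "the series" means these compounds.

Series notes. Compound 1 `Cc1c(OCCCCOc2ccc(C(=O)O)c(Cl)c2)ccc(C(=O)CC(C)C)c1O` in an assay on HEK293 cells for positive allosteric modulation of metabotropic glutamate receptor 3 (Rattus norvegicus), read by thallium flux, with a stated time of 2.5 min (on this read-out higher numbers stand for an effect only at larger amounts of compound and lower numbers for an effect already at smaller amounts), gives 2050 nM. Compound 2 `CC(=O)c1ccc(OCCCCOc2ccc(C(=O)O)cc2C)c(C)c1O` carries an acetyl where compound 1 carries an isobutylcarbonyl; in this assay compound 2 gives "not determined" (no result reported), so compound 2 stands nowhere on the measured scale. Compound 3 `Cc1cc(C(=O)O)ccc1OCCCCOc1ccc(C(=O)CC(C)C)c(O)c1C` differs from compound 2 by isopropyl in place of hydrogen on a saturated chain carbon bound to a carbonyl carbon. Among the measured compounds shown here, no measured pair shows this change, so the size and direction of the step in this assay from compound 2 to compound 3 cannot be read from the data. Compound 3 shares the isobutylcarbonyl with compound 1, which gives 2050 nM. Compound 3 is therefore expected to land near that, at an estimated 2000 nM, within 500 nM to 8000 nM.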

Compound 3, half-maximal effective concentration: 1850 nM
Compound 3: the middle estimate sits 1.1-fold (0.03 log units) above what was measured, and the stated range covers the measured number.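

In this assay, 4-carboxy-2-methylphenyl in place of 4-carboxy-3-chlorophenyl on an oxygen on a saturated carbon gives a 1.1-fold lower number from compound 1 to compound 3 (0.04 log units; within the scatter), so with the isobutylcarbonyl held fixed, this exchange does not separate the two compounds on the read-out. No supporting data bear on this result. The step from methyl to isobutyl cannot be read, as compound 2 has no number. Open, on these data alone, is how a longer chain or a cyclopropyl in place of the isobutyl, or a fluorine in place of the chlorine, would read.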